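A few compounds are considered here, and "the series" means these few. Any claim that something is new, unique, unknown or untested is made for them only; others in the source may bear on it.

Within the data shown here, compound 2 `COc1ccccc1/C=c1\c(=O)[nH]/c(=C/c2ccccc2Cl)c(=O)n1C` gives 200 nM in a functional assay on MCF7 cells (Homo sapiens) for cytotoxicity, read by CCK-8 assay, with a stated time of 72 h (a lower number here means a stronger inhibitor, a higher number a weaker inhibitor), the lowest of the two numbers so far. Compound 3 `C=CCn1c(=O)/c(=C\c2ccccc2C(F)(F)F)[nH]c(=O)/c1=C\c1ccccc1OC` gives 6500 nM in this assay, a far higher number than compound 2, beyond the usual scatter. Compound 1 `C=CCn1c(=O)/c(=C\c2ccc(Cl)c(Cl)c2)[nH]c(=O)/c1=C\c1ccccc1` is reported as "not active" (no number reported) in this assay, with no number attached.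

Compound 4 `COc1ccccc1/C=c1/[nH]c(=O)/c(=C\c2ccccc2OC)n(C)c1=O` has not yet been measured. It differs from compound 2 in one place: methoxy in place of chloro on an aromatic carbon. The change, cut one bond further out, reads as 2-chlorophenyl to 2-methoxyphenyl, so compound 4 carries a methoxy on each of its two outer rings.

Among the measured compounds shown here, no measured pair shows this exact change, so the size of the step is open. For the measured compounds named here, the only comparison is that compound 3, which also carries a 2-methoxyphenyl but a different partner ring and a different group on the core nitrogen, sits well above compound 2. A modest weakening, possibly within the scatter, is expected from compound 2 to compound 4 a 2.3-fold higher number from compound 2 to compound 4 (0.35 log units; beyond the scatter). Compound 4 is estimated at 450 nM, with a range from 120 nM to 2500 nM.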

Compound 4, half-maximal inhibitory concentration: 9000 nM
Estimate against measurement, compound 4: 20-fold (1.30 log units) below; measured number above the stated range.
By their numbers in this assay, from the lowest: compound 2; then compounds 3 and 4 (each within the scatter of the next).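

Methoxy in place of chloro on an aromatic carbon, ortho to a large group, turns out to be a far from neutral exchange in this assay, giving a 45-fold higher number from compound 2 to compound 4 (1.65 log units; beyond the scatter). Among these compounds, this is the first single-place comparison, and it shows that, with the rest of the molecule held constant, the outcome at this ring position depends strongly on which of these two groups is present. No measurement shown here accounts for the size of this step.

Among the compounds shown here, no other pair carries the same change, so whether the step keeps its size with a different partner ring or a different group on the core nitrogen remains open. Also open, going by these compounds, is how an amine, a hydroxyl or a fluoro at this position would compare with the chloro of compound 2.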